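Quinoxaline series: amino-to-imine exchange on the aryl ether

This account rests on a few compounds, and the source may have more. Where it says the series, first, only, none or still open, it means among the compounds named here.

Measured so far:
- compound 1 `Cc1nc2cc(Br)ccc2nc1Nc1ccc(S(=O)(=O)N2CCCCC2)cc1`: 0.00162 ug/mL
- compound 2 `Cc1nc2cc(Br)ccc2nc1NN`: 0.0243 ug/mL
- compound 3 `Cc1nc2cc(Br)ccc2nc1Oc1ccc(N)cc1`: 0.00081 ug/mL

In a functional assay on MCF7 cells (Homo sapiens) for inhibition, read by sulforhodamine B assay, with a stated time of 72 h (a higher number here means a weaker inhibitor, a lower number a stronger inhibitor), compound 3 gives 0.00081 ug/mL, the lowest of the three numbers. Compound 1 stands nearest, within the scatter, so the two cannot be told apart on these values. Compound 2 gives 0.0243 ug/mL, a number well beyond the scatter from compound 3. Within the data shown here, no pairs differing in one place are present among the measured compounds, so no step size is known from the data.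

Compound 4 `Cc1nc2cc(Br)ccc2nc1Oc1ccc(/C=N\c2ccc(Cl)cc2)cc1` differs from compound 3 in one place: a group of 9 heavy atoms (7 carbon, 1 nitrogen, 1 chlorine; one six-membered aromatic ring of carbon only) in place of one nitrogen atom, on an aromatic carbon, para to a large group.

Among the measured compounds shown here, with no measured step to lean on, the expected change is a modest weakening, possibly no more than the scatter. Compound 4 is estimated at 0.002 ug/mL in this assay, with a range from 0.0005 ug/mL to 0.01 ug/mL; this means an expected step of a 2.5-fold higher number from compound 3 to compound 4 (0.39 log units; beyond the scatter).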

Compound 4, half-maximal inhibitory concentration: 0.0126 ug/mL
Compound 4: middle estimate off by 6.3-fold (0.80 log units), on the low side; the whole stated range lies below it.
By their numbers in this assay, from the lowest: compounds 3 and 1 (each within the scatter of the next); then compounds 4 and 2 (each within the scatter of the next).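

In this assay, among these compounds, the exchange of the amino group for the imine group of 9 heavy atoms gives a 16-fold higher number from compound 3 to compound 4 (1.19 log units; beyond the scatter) and is the first measured step at this position, on an aromatic carbon para to a large group. The position is therefore not indifferent to what it carries, and this larger group, which has no hydrogen-bond donor where the amino group has one, costs clearly more than the scatter. Nothing measured here accounts for the size of this step.

This single exchange does not separate the contributions of the double bond, the added aromatic ring and the chlorine. An imine with an unsubstituted phenyl ring, or a small group at the same place such as methoxy or acetamide, would show which of these parts carries the loss.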